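Cyclopropylmethyl on the ring nitrogen of the shared core

The source may hold more compounds than are shown below. What is called first, only, known or untested is meant among the compounds shown, and "the series" means these compounds.

Among the measured compounds shown here, compound 2 `CC(C)c1onc(-c2c(Cl)cccc2Cl)c1COc1ccc(-c2nc3ccc(C(=O)O)cc3n2-c2ccc(F)cc2)cc1` is one of two compounds measured so far in an assay on isolated protein for agonist activity at Bile acid receptor (Homo sapiens), read by TR-FRET; on this read-out higher numbers stand for an effect only at larger amounts of compound and lower numbers for an effect already at smaller amounts. In this assay, for the measured compounds named here, compound 2 gives 15.1 nM, and the only other point is compound 1 `CCCC(CCC)n1c(-c2ccc(OCc3c(-c4c(Cl)cccc4Cl)noc3C(C)C)cc2)nc2ccc(C(=O)O)cc21`, which in this assay gives 30.3 nM; the two sit within the scatter of each other, so no order between them is claimed. Going by the values given here, the one recorded step, a 2.0-fold lower number from compound 1 to compound 2 (0.30 log units; within the scatter), exchanges a 1-propylbutyl for a 4-fluorophenyl on the aromatic nitrogen of the shared core.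

Compound 3 `CC(C)c1onc(-c2c(Cl)cccc2Cl)c1COc1ccc(-c2nc3ccc(C(=O)O)cc3n2CC2CC2)cc1` carries the change (cyclopropylmethyl in place of 4-fluorophenyl on an aromatic nitrogen). Among the compounds with values here, the only step that bears on this site is a 2.0-fold lower number from compound 1 to compound 2 (0.30 log units; within the scatter), and it stayed within the scatter; the new group resembles neither of the two groups already tried at this nitrogen, so the step to compound 3 rests on thin ground. On that basis the change to compound 3 is expected to be a 1.7-fold higher number from compound 2 to compound 3 (0.22 log units; within the scatter), with no movement beyond the scatter anticipated in this assay. Compound 3 is therefore estimated at 25 nM, within a range of 8 nM to 80 nM.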

Compound 3, half-maximal effective concentration: 29.1 nM
Estimate against measurement, compound 3: 1.2-fold (0.07 log units) below; low and high end bracket the measured number.
By their numbers in this assay, from the lowest: compounds 2, 3 and 1 (each within the scatter of the next).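

The exchange of 4-fluorophenyl for cyclopropylmethyl on the aromatic nitrogen gives a 1.9-fold higher number from compound 2 to compound 3 (0.28 log units; within the scatter), and the exchange of 1-propylbutyl for cyclopropylmethyl gives a 1.0-fold lower number from compound 1 to compound 3 (0.02 log units; within the scatter), so no order among the three compounds can be drawn in this assay. The new point adds a group with a three-membered non-aromatic ring and 4 heavy atoms to the set at this nitrogen, where 4-fluorophenyl has a six-membered aromatic ring and 7 heavy atoms, and neither that difference in ring type nor the one in heavy-atom count separates compound 2 from compound 3 beyond the scatter. Nothing among the data available accounts for why these groups read alike.

Going by these compounds, it remains open whether a much smaller group such as methyl, or a chain ending in an amine or a hydroxyl, on this aromatic nitrogen would give a step beyond the scatter. On these data alone, the three compounds also share every other part of the structure, so whether the same holds with another group in place of the isopropyl or the carboxylic acid is equally open.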